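Swapping the Aryl Substituent in a Two-Compound Series

The compounds below may be only part of what the source reports. "The series", "measured", "known", "first", "only" and "open" are said of these compounds alone.

For the measured compounds named here, compound 2 `COc1cc(C(=O)c2sc(-c3ccc(C(F)(F)F)cc3)cc2N)cc(OC)c1OC` stands highest of the two numbers measured so far: in a functional assay on MOLT-4 cells (Homo sapiens) for antiproliferative activity (on this read-out higher numbers stand for weaker inhibition and lower numbers for stronger inhibition), compound 2 gives 250 nM, whereas compound 1 `COc1cc(C(=O)c2sc(-c3ccc(C)cc3)cc2N)cc(OC)c1OC` gives 16 nM. Going by the values given here, the single measured step, trifluoromethyl replacing methyl on an aromatic carbon, was a 16-fold higher number from compound 1 to compound 2 (1.19 log units; beyond the scatter). Compound 3 `COc1cccc(-c2cc(N)c(C(=O)c3cc(OC)c(OC)c(OC)c3)s2)c1` differs from compound 2 by 3-methoxyphenyl in place of 4-(trifluoromethyl)phenyl on an aromatic carbon. That measured step bears only loosely on this change, since the entering group is neither methyl nor trifluoromethyl. The step expected here is a 4.2-fold lower number from compound 2 to compound 3 (0.62 log units; beyond the scatter). Compound 3 is therefore estimated at 60 nM, within 15 nM to 250 nM.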

Compound 3, half-maximal inhibitory concentration: 17 nM
Estimate against measurement, compound 3: 3.5-fold (0.55 log units) above; measured number inside the range.
By their numbers in this assay, from the lowest: compounds 1 and 3 (each within the scatter of the next); then compound 2.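

In this assay, 3-methoxyphenyl in place of 4-(trifluoromethyl)phenyl gave a 15-fold lower number from compound 2 to compound 3 (1.17 log units; beyond the scatter), showing that this position next to the ring sulfur can carry a substituted phenyl other than 4-methylphenyl without a measurable loss. Against compound 1 the same swap gave a 1.1-fold higher number from compound 1 to compound 3 (0.03 log units; within the scatter), so among these three compounds only the 4-(trifluoromethyl)phenyl group stands apart. Nothing available here explains that gap. Going by these compounds, it remains open how 4-methoxyphenyl would compare with 3-methoxyphenyl. On these data alone, it is also open whether a chlorine, a nitrile or an amine on the phenyl ring would track compound 2 or compounds 1 and 3.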